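The source may hold more compounds than are shown below. What is called first, only, known or untested is meant among the compounds shown, and "the series" means these compounds.

Working notes on the series. Compound 1 `O=C(CCCCC1CCSS1)NCc1cn(CCCOc2ccc3ccc(=O)oc3c2)nn1`, compound 2 `CCOC(=O)c1cc2ccc(OCCCn3cc(CNC(=O)CCCCC4CCSS4)nn3)cc2oc1=O` and compound 3 `O=C(CCCCC1CCSS1)NCc1cn(CCCOc2ccc3cc(-c4ccccc4)c(=O)oc3c2)nn1` share one core. In a functional assay on PC-12 cells (Rattus norvegicus) for cytotoxicity, read by MTT assay, with stated times of 3 h and 2 h, tested at 20 uM (a higher number here means a stronger effect of the compound at the concentration tested, a lower number a weaker effect), compound 1 gives 42.2%, compound 2 gives 42.1% and compound 3 gives 27.2%, the lowest of the three numbers. The measured steps read a number 0.1 percentage points lower from compound 1 to compound 2 (within the scatter), a number 15 percentage points lower from compound 1 to compound 3 (beyond the scatter) and a number 14.9 percentage points lower from compound 2 to compound 3 (beyond the scatter). Compound 4 `O=C(CCCCC1CCSS1)NCc1cn(CCCOc2ccc3cc(-c4ccc(Cl)cc4)c(=O)oc3c2)nn1` differs from compound 3 by chloro in place of hydrogen on an aromatic carbon. Within the data shown here, no measured step covers this change: the two steps beyond the scatter, a number 15 percentage points lower from compound 1 to compound 3 (beyond the scatter) and a number 14.9 percentage points lower from compound 2 to compound 3 (beyond the scatter), concern the phenyl itself, not a substituent on it, so nothing measured here points in either direction. The step expected in this assay is therefore none beyond the scatter, a number 0.2 percentage points lower from compound 3 to compound 4 (within the scatter). Compound 4 is expected to give 27%, with a range from 14% to 40%.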

Compound 4, a percentage reported as activity, at one concentration (the size of the read-out at that concentration, not a potency): 75.6%
For compound 4 the middle estimate is 48.6 percentage points below the measured one; measured number above the stated range.
By their numbers in this assay, from the lowest: compound 3; then compounds 2 and 1 (each within the scatter of the next); then compound 4.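

In this assay the 4-chlorophenyl gives a number 48.4 percentage points higher from compound 3 to compound 4 (beyond the scatter), so the read-out at this position depends on what the phenyl carries and not on the phenyl alone. The same group reverses the fall seen with plain phenyl and gives a number 33.4 percentage points higher from compound 1 to compound 4 (beyond the scatter) and a number 33.5 percentage points higher from compound 2 to compound 4 (beyond the scatter). Nothing measured here accounts for a step of this size.

From the compounds shown here alone, whether this step belongs to chlorine or to any substituent at this place remains open, and a fluoro, a methoxy or an amine there would test that. Going by these compounds, whether chloro elsewhere on the phenyl gives the same step also remains open.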